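Ethoxy in place of dimethylamino on a carbonyl carbon

The source may report more compounds than this note shows. Statements on the series, on what has been measured and on what is new or still open speak of the compounds shown alone.

Measured so far in a physicochemical assay for lipophilicity (on this read-out higher numbers stand for higher lipophilicity and lower numbers for lower lipophilicity), are three compounds
compound 1 `C/C=C/C=C/C(=O)Nc1ccc(OC)cc1` gives 2.28
compound 2 `C/C=C/C=C/C(=O)Nc1ccc(Br)cc1` gives 3.32
compound 3 `C/C=C/C=C/C(=O)N(C)C` gives 1.1

Compound 3 stands lowest of these three numbers, and its partner here, compound 4 `C/C=C/C=C/C(=O)OCC`, has yet to be measured. The change is ethoxy in place of dimethylamino on a carbonyl carbon, counted as ethoxy in place of dimethylamino on a carbonyl carbon in full. For the measured compounds named here, the only measured step, a number 1.04 log units higher from compound 1 to compound 2 (beyond the scatter) on an aromatic carbon, involves other groups at another place, so it bears only loosely. Going by the values given here, it shows that a single exchange can move this assay by a large amount, yet no measured step covers this exchange. On that thin basis, a large upward step is expected, estimated as a number 1.50 log units higher from compound 3 to compound 4 (beyond the scatter) in this account. Compound 4 is expected at 2.6 within an estimated range from 2.2 to 3 on this reasoning.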

Compound 4, partition coefficient: 1.84
Estimate against measurement, compound 4: 0.76 log units above, outside the stated range (below it).
By their numbers in this assay, from the lowest: compound 3; then compound 4; then compound 1; then compound 2.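

In this assay ethoxy in place of dimethylamino on a carbonyl carbon gives a number 0.74 log units higher from compound 3 to compound 4 (beyond the scatter) and so shows that this position responds to the exchange even with the heavy-atom count unchanged. The two groups differ by an oxygen for a nitrogen and one carbon-bearing branch, and the step counts as modest. Nothing measured here explains its size. From the compounds shown here alone, whether a longer chain on the oxygen, a carboxylic acid or a secondary amine on this carbonyl carbon would move the read-out further stays open. So does whether the step holds on another core.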